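Geometry of the stilbene bridge in the urea analogue

The source may report more compounds than this note shows. Statements on the series, on what has been measured and on what is new or still open speak of the compounds shown alone.

Compound 1 `CCNC(=O)Nc1ccc(/C=C\c2cc(OC)c(OC)c(OC)c2)cc1` carries an (ethylcarbamoyl)amino group on the aromatic carbon and a Z-drawn double bond. Within the data shown here, in a functional assay on M21 cells (Homo sapiens) for inhibition, read by sulforhodamine B assay, with a stated time of 48 h (on this read-out higher numbers stand for weaker inhibition and lower numbers for stronger inhibition), compound 1 gives 21000 nM, the highest of the three numbers so far; compound 2 `O=C1NCCN1c1ccc(/C=C/c2cccc(Cl)c2)cc1` gives 19000 nM, within the scatter of compound 1, while compound 3 `COc1cc(/C=C\c2ccc(N3CCNC3=O)cc2)cc(OC)c1OC` gives 2.4 nM. Among the measured compounds shown here, the one measured step, an 8800-fold lower number from compound 1 to compound 3 (3.94 log units; beyond the scatter), is a group swap and says nothing about double-bond configuration. Compound 4 `CCNC(=O)Nc1ccc(/C=C/c2cc(OC)c(OC)c(OC)c2)cc1` differs from compound 1 only as follows: the two compounds have the same atoms and bonds and differ only in configuration as drawn: 1 of 1 stereo elements differ; a double bond is drawn Z in compound 1 and E in compound 4. For the measured compounds named here, no measured step changes configuration alone; compound 2 is drawn E but also carries a different ring and a different group, so its value cannot be read as a geometry effect. With the starting number already at the weak end of the series, the expected step of a 1.9-fold higher number from compound 1 to compound 4 (0.28 log units; within the scatter) is a modest move toward a higher number, possibly inside the scatter. Compound 4 is therefore estimated at 40000 nM, with a range from 10000 nM to 150000 nM, and a real chance that this assay returns only a limit.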

Compound 4, half-maximal inhibitory concentration: 29000 nM
Compound 4: middle estimate off by 1.4-fold (0.14 log units), on the high side, and the stated range covers the measured number.
By their numbers in this assay, from the lowest: compound 3; then compounds 2, 1 and 4 (each within the scatter of the next).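

Among these compounds, this is the first step that reads double-bond configuration on its own: the fact that compounds 1 and 4 differ only in the configuration as drawn. In this assay, the change from the Z-drawn to the E-drawn double bond gives a 1.4-fold higher number from compound 1 to compound 4 (0.14 log units; within the scatter), so with the (ethylcarbamoyl)amino group on the aromatic carbon, configuration does not separate the pair. The large move in the series remains the group swap, an 8800-fold lower number from compound 1 to compound 3 (3.94 log units; beyond the scatter), in which the double bond is drawn Z on both sides.

The compounds shown include no E-drawn partner of compound 3, so whether configuration matters with the 2-oxoimidazolidin-1-yl group in place remains open. Also open, going by these compounds, is how a simple amine or a carboxylic acid on that aromatic carbon would compare with the 2-oxoimidazolidin-1-yl group of compound 3.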